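The source may report more compounds than this note shows. Statements on the series, on what has been measured and on what is new or still open speak of the compounds shown alone.

Measured so far in a functional assay on NIH3T3 cells (Mus musculus); a lower number here means that less compound is needed, a higher number that more compound is needed for the effect:
Compound 1, `CSCC[C@H](NC(=O)c1ccc(NCc2cncn2Cc2ccccc2C)cc1-c1ccccc1)C(=O)O`: a limit only, > 10 uM.
Compound 2, `CSCC[C@H](NC(=O)c1ccc(NCc2cncn2Cc2cccc(Cl)c2)cc1-c1ccccc1)C(=O)O`: a limit only, > 10 uM.
Compound 3, `COC(=O)[C@H](CCSC)NC(=O)c1ccc(NCc2cncn2Cc2cccc(Cl)c2)cc1-c1ccccc1`: a limit only, > 10 uM.

Compound 3 thus stands at a limit of this assay rather than at a number, and every value in the set is such a limit (the limit of > 10 uM in this assay, at which 3 of the 3 values shown sit). The two measured steps, a step that the two limits leave unreadable from compound 1 to compound 2 and a step that the two limits leave unreadable from compound 2 to compound 3, carry no readable size, so neither direction nor magnitude can be taken from them. Compound 4, `COC(=O)[C@H](CCSC)NC(=O)c1ccc(NCc2cncn2Cc2cccc(C)c2)cc1-c1ccccc1`, differs from compound 3 by methyl in place of chloro on an aromatic carbon, a change from 3-chlorobenzyl to 3-methylbenzyl. Within the data shown here, no measured step bears on this exchange beyond (the limit of > 10 uM in this assay, at which 3 of the 3 values shown sit). The step that the limit leaves unreadable from compound 3 to compound 4 is therefore expected to remain unreadable, with compound 4 most likely again at the limit. Compound 4 is estimated at 20 uM, with a range from 8 uM to 60 uM.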

Compound 4, concentration for half-maximal effect: > 10 uM
Compound 4: no number, only a limit (the forecaster's own chance of this, stated with the estimate: 85%); the middle value is on the limit's open side.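

No readable step comes from the exchange between compound 3 and compound 4, as both values are limits in this assay. The compounds shown leave open what potency any of them has beyond that limit: the limit of > 10 uM in this assay, at which 4 of the 4 values shown sit.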